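Bromoethyl replacing cyclopropyl on the ring-nitrogen side chain

A few compounds are considered here, and "the series" means these few. Any claim that something is new, unique, unknown or untested is made for them only; others in the source may bear on it.

Compound 1 `CCCCCCCc1cc2c(=O)n(CC#N)cnc2s1` gives a limit in an ADME assay on MCF7 cells (Homo sapiens) for cytotoxicity, read by MTT assay, with a stated time of 11 days (a lower number here means a stronger inhibitor of growth, a higher number a weaker inhibitor of growth), of > 100 ug/mL.
Compound 2 `CCCCCCCc1cc2c(=O)n(CC3CC3)cnc2s1` gives a limit in this assay of > 100 ug/mL.

Both values are limits of this assay, not numbers, so compound 2 stands at the same limit as compound 1 and its true position cannot be fixed more closely. Among the compounds with values here, the only measured step, a step that the two limits leave unreadable from compound 1 to compound 2, is therefore unreadable in size. Compound 3 `CCCCCCCc1cc2c(=O)n(CCCBr)cnc2s1` differs from compound 2 by a change on the same side chain: 2-bromoethyl in place of cyclopropyl on a saturated chain carbon bound to an aromatic nitrogen. Within the data shown here, no measured step bears directly on this exchange, and the one step available gives no size at all. What the two measured compounds share is that (the limit of > 100 ug/mL in this assay, at which 2 of the 2 values shown sit), so there is nothing to suggest that the side chain on the aromatic nitrogen moves the read-out in either direction. Compound 3 is expected to sit near the same limit, a step of a number no higher from compound 2 to compound 3 (the limit leaves the size open) amounting to none beyond the scatter. The estimate for compound 3 in this assay is 100 ug/mL, with a range from 35 ug/mL to 300 ug/mL, and the assay may well again report only a limit.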

Compound 3, concentration for 50% growth inhibition: 19.7 ug/mL
Estimate against measurement, compound 3: 5.1-fold (0.71 log units) above; the whole stated range lies above it.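

In this assay, the group on the saturated chain carbon bound to an aromatic nitrogen proves able to move the read-out: 2-bromoethyl in place of cyclopropyl gives an at least 5.0-fold lower number from compound 2 to compound 3 (0.70 log units; beyond the scatter), and 2-bromoethyl in place of cyano gives an at least 5.0-fold lower number from compound 1 to compound 3 (0.70 log units; beyond the scatter). Both steps start from limits rather than numbers, so each gives only a smallest size, and the step between the two earlier compounds cannot be read. Compound 3 is the only one of the three with a number in this assay, and the other two stay at the limit, which is not a number: the limit of > 100 ug/mL in this assay, at which 2 of the 3 values shown sit.

The compounds shown do not separate the bromine atom from the loss of the three-membered ring, so it remains open which of the two goes with the lower number. As far as these compounds go, how a plain propyl chain, a chloroethyl group or an amine would read in the same place also remains open, as does the true position of compound 1 and compound 2 beyond their limits.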